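The source may report more compounds than this note shows. Statements on the series, on what has been measured and on what is new or still open speak of the compounds shown alone.

Working notes on the series. Compound 1 `CC(C)Nc1nc(NCc2ccco2)c2cccc(Cl)c2n1` and compound 2 `CC(C)Nc1nc(NCc2ccco2)c2c(Cl)cccc2n1` are built from the same atoms joined differently; the difference between the two cores is not broken down here. Going by the values given here, in a physicochemical assay for lipophilicity, at pH 7.4 (a higher number here means a more lipophilic compound, a lower number a more polar compound), compound 1 gives 3.96, while compound 2 gives 4.44, the highest of the three numbers measured so far. Compound 3 `Cc1cccc2c(NCc3ccco3)nc(NC(C)C)nc12` differs from compound 1 in one place only, (methyl in place of chloro on an aromatic carbon), and in this assay compound 3 gives 3.55; the step is a number 0.41 log units lower from compound 1 to compound 3 (beyond the scatter). Compound 2 thus stands above compound 1 and further above compound 3, both gaps beyond the scatter.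

Compound 4 `Cc1cccc2nc(NC(C)C)nc(NCc3ccco3)c12` has not yet been measured. It is derived from compound 2 by methyl in place of chloro on an aromatic carbon. The description of the place reads the same, word for word, as for the change from compound 1 to compound 3, so this is the same change, made on the core of compound 2 rather than on that of compound 1. Among the compounds with values here, the expected step in this assay is a number 0.41 log units lower from compound 2 to compound 4 (beyond the scatter), which rests on the single measured instance of this exchange, a number 0.41 log units lower from compound 1 to compound 3 (beyond the scatter), set beside it; with only one precedent, the direction of the step is taken as more dependable than its exact size. For compound 4 the estimate in this assay is 4.03, with an expected range from 3.7 to 4.36.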

Compound 4, distribution coefficient: 3.55
Estimate against measurement, compound 4: 0.48 log units above; measured number outside the range, below it.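

In this assay the exchange of methyl for chloro on an aromatic carbon now has two instances, the earlier one being a number 0.41 log units lower from compound 1 to compound 3 (beyond the scatter) and the new one being a number 0.89 log units lower from compound 2 to compound 4 (beyond the scatter) on the core of compound 2, so the direction of the step held on both cores shown. The size did not carry over, since the new step is the larger of the two, which shows that the number from one core cannot simply be added on the other; two pairs give no rule for the size of the step on any further core, and they do not show that the direction would hold there. Nothing given here bears on why the step differs in size between these two cores.

The compounds shown leave open how other groups at these places would compare, such as an amine or a carboxylic acid in place of the chloro or the methyl, since only those two groups appear there. They also leave open whether the step would keep its direction with a longer chain in place of either of the two side chains, which stay the same in all four compounds.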